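Fluoro to Bromo on One Aromatic Ring

The source may hold more compounds than are shown below. What is called first, only, known or untested is meant among the compounds shown, and "the series" means these compounds.

Measured so far:
compound 1, `O=C1/C(=C/c2ccccc2)CCC/C1=C\c1ccccc1Br`, gives 46.8% in an assay on isolated protein for inhibition of Alpha glucosidase (Homo sapiens), with stated times of 5 min and 15 min, tested at 50 uM; a lower number here means less inhibition, a higher number more inhibition at the concentration tested (going by the name of the read-out)
compound 2, `O=C1/C(=C/c2ccccc2)CCC/C1=C\c1cccc(F)c1`, gives 39.8% in this assay

Both compounds share a core with two aromatic rings hung from it; they differ only in the group on one of those rings. In this assay compound 2 stands lowest of the two numbers, and its nearest neighbour is compound 1, separated by a number 7 percentage points lower from compound 1 to compound 2 (within the scatter). That single step pairs a change of halogen with a change of where the halogen sits, so it speaks only partly to what follows.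

Compound 3, `O=C1/C(=C/c2ccccc2)CCC/C1=C\c1cccc(Br)c1`, carries bromo in place of fluoro on an aromatic carbon. Within the data shown here, the only measured step that bears on this is the one from compound 1 to compound 2, which stayed within the scatter. Because that step was a number 7 percentage points lower from compound 1 to compound 2 (within the scatter), compound 3 is expected to show a change of a number 4.2 percentage points higher from compound 2 to compound 3 (within the scatter), a step of no clear size beyond the scatter and, if anything, tilted upward toward the number of compound 1. The estimate for compound 3 in this assay is 44%, within a range from 30% to 58%.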

Compound 3, a percentage reported as inhibition, at one concentration (the size of the read-out at that concentration, not a potency): 27.2%
For compound 3 the middle estimate is 16.8 percentage points above the measured one; the measured number lies below the stated range.
By their numbers in this assay, from the lowest: compound 3; then compounds 2 and 1 (each within the scatter of the next).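

With the halogen kept at the same place on the ring, the change from 3-fluorophenyl to 3-bromophenyl alone shifts the result in this assay by more than the scatter (a number 12.6 percentage points lower from compound 2 to compound 3 (beyond the scatter)), so at this spot the choice of halogen matters, and bromo goes with the lower inhibition of the pair. With the halogen kept the same, moving the bromo also gives a step beyond the scatter (a number 19.6 percentage points lower from compound 1 to compound 3 (beyond the scatter)), so its place on the ring matters too, and the 2-bromophenyl compound has the higher number of the two; the earlier step from compound 1 to compound 2 changed halogen and place together and could separate neither. No measurement at hand offers a reason for either step.

The compounds shown leave open how a group other than a halogen, such as a methoxy group, an amine or a carboxylic acid, would behave at the spot that carries the bromo in compound 3. They also leave open whether fluoro and bromo would fall in the same order on the ring as it stands in compound 1.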